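From compound 3 to the open-chain amine compound 4

A few compounds are considered here, and "the series" means these few. Any claim that something is new, unique, unknown or untested is made for them only; others in the source may bear on it.

Measured in an ADME assay on microsomes from liver (Homo sapiens) for metabolic stability, read by LC-MS, tested at 1 uM; on this read-out lower numbers stand for slow clearance and higher numbers for fast clearance:
Compound 1 `NCCCOc1ccc([C@H]2CC[C@]3(CC2)OOC2(O3)C3CC4CC(C3)CC2C4)cc1` gives < 7 mL.min-1.g-1 as a limit of the assay
Compound 2 `OC1(COc2ccc([C@H]3CC[C@]4(CC3)OOC3(O4)C4CC5CC(C4)CC3C5)cc2)CCNCC1` gives 16 mL.min-1.g-1
Compound 3 `CC(C)(O)CN1CCC(Oc2ccc([C@H]3CC[C@]4(CC3)OOC3(O4)C4CC5CC(C4)CC3C5)cc2)CC1` gives 18 mL.min-1.g-1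

Compound 3 stands level with compound 2, and a 1.1-fold higher number from compound 2 to compound 3 (0.05 log units; within the scatter) makes the two indistinguishable. Both carry a piperidin-4-yl ring in the group on the oxygen, whereas compound 1 carries the open 3-aminopropyl chain. The next compound, compound 4 `CC(C)(N)CCOc1ccc([C@H]2CC[C@]3(CC2)OOC2(O3)C3CC4CC(C3)CC2C4)cc1`, replaces the group of compound 3 with an open chain: 3-amino-3-methylbutyl in place of 1-(2-hydroxy-2-methylpropyl)piperidin-4-yl on an oxygen on an aromatic ring in full.

The closest measured step is an at least 2.5-fold higher number from compound 1 to compound 3 (0.41 log units; beyond the scatter) and it joins the same group to an open chain. On these data alone, also relevant is an at least 2.2-fold higher number from compound 1 to compound 2 (0.35 log units; beyond the scatter) and both steps start from the limit of < 7 mL.min-1.g-1 in this assay, at which 1 of the 3 values shown sits, so their full size remains open. Run in reverse, they suggest a fall from compound 3 towards compound 1, although no measured compound carries the new chain itself, so the step is expected to be only part of that distance. The expected change is a 2.3-fold lower number from compound 3 to compound 4 (0.35 log units; beyond the scatter) as a modest step to a lower number. In this assay compound 4 is estimated at 8 mL.min-1.g-1 with an expected range from 4 mL.min-1.g-1 to 18 mL.min-1.g-1.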

Compound 4, intrinsic clearance in microsomes: < 7 mL.min-1.g-1
Compound 4 gave a limit, no number; the forecaster's own chance of this, stated with the estimate: 40%; middle value at least 1.1-fold (0.05 log units) from the limit.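

Moving from the piperidin-4-yl groups to the open 3-amino-3-methylbutyl chain on the oxygen lowers the reading in this assay beyond the scatter, with an at least 2.5-fold lower number from compound 3 to compound 4 (0.41 log units; beyond the scatter) and an at least 2.2-fold lower number from compound 2 to compound 4 (0.35 log units; beyond the scatter). Until now the open 3-aminopropyl chain of compound 1 was the only open chain shown, so the low reading rested on a single example; compound 4 gives < 7 mL.min-1.g-1, which is a limit of the assay and not a number, and so provides a second open chain, with two methyl groups on the carbon that bears the amine. Among these four compounds, the two with open amine chains sit at the limit and the two with a piperidin-4-yl ring give numbers, with none going against this, but the step from compound 1 to compound 4 cannot be read: the limit of < 7 mL.min-1.g-1 in this assay, at which 2 of the 4 values shown sit.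

On these data alone, how far either open-chain compound lies past the limit remains open, and with it whether the two added methyl groups change the reading at all. Both ring compounds also carry a hydroxyl group and neither open chain does, so a piperidin-4-yl group without a hydroxyl, or an open amine chain with one, would be needed to tell the ring from the hydroxyl.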